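Sulfonyl substituent change on the shared core

This account rests on a few compounds, and the source may have more. Where it says the series, first, only, none or still open, it means among the compounds named here.

Measured so far in a functional assay on KOPN-8 cells (Homo sapiens) for antiproliferative activity, with a stated time of 72 h; on this read-out higher numbers stand for an effect only at larger amounts of compound and lower numbers for an effect already at smaller amounts:
- compound 1 `COc1ccc(-c2[nH]c3cc(OC)cc(OC)c3c(=O)c2I)cc1`: 49400 nM
- compound 2 `COc1ccc(-c2c(I)c(=O)c3c(OC)cc(OC)cc3n2S(=O)(=O)c2ccc(OC)cc2)cc1`: 8580 nM
- compound 3 `COc1ccc(-c2cc(=O)c3c(OC)cc(OC)cc3n2S(=O)(=O)c2ccc(C)c([N+](=O)[O-])c2)cc1`: only a limit, > 51700 nM

Compound 3 gives no number in this assay but a limit, (the limit of > 51700 nM in this assay, at which 1 of the 3 values shown sits), so its standing among the three is known only as the least defined end of the set. Among the measured compounds shown here, the one measured step that gives a number is a 5.8-fold lower number from compound 1 to compound 2 (0.76 log units; beyond the scatter), and it concerns a (4-methoxyphenyl)sulfonyl in place of hydrogen on an aromatic nitrogen while the rest of compound 1 is kept. For the measured compounds named here, compound 2 and compound 3 have no step between them; their values show that compound 2 gives a number where compound 3 gives only a limit.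

Compound 4 `COc1ccc(-c2cc(=O)c3c(OC)cc(OC)cc3n2S(=O)(=O)Cc2ccccc2)cc1` is not yet measured. It differs from compound 3 by benzyl in place of 4-methyl-3-nitrophenyl on a sulfonyl sulfur. Going by the values given here, no measured step changes the group on the sulfonyl sulfur, so nothing here tells the size or direction of this change in this assay. The benzyl of compound 4 is expected to leave the compound near the limit of compound 3, with a step of an at least 1.2-fold lower number from compound 3 to compound 4 (0.11 log units; that floor lies within the scatter) expected at most. Compound 4 is therefore estimated at 40000 nM in this assay, with a range of 10000 nM to 100000 nM.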

Compound 4, half-maximal effective concentration: > 34400 nM
Compound 4: only a limit was reported; the forecaster's own chance of this, stated with the estimate: 50%; the middle value lies beyond the limit too.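

In this assay compound 4 gives only a limit: the limit of > 34400 nM in this assay, at which 1 of the 4 values shown sits.
Compound 3 also gives only a limit: the limit of > 51700 nM in this assay, at which 1 of the 4 values shown sits.
Among the compounds shown here, with a limit on each side, no step from compound 3 to compound 4 can be read. The compounds shown leave open whether changing the group on the sulfonyl sulfur shifts this read-out at all.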